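Cytotoxicity of coumarin-type analogues: a halogen swap

The compounds below may be only part of what the source reports. "The series", "measured", "known", "first", "only" and "open" are said of these compounds alone.

Measured so far:
compound 1, `Cc1c(Cc2ccccc2)c(=O)oc2cc(OCC(O)CNC3CCOCC3)ccc12`, 38200 nM
compound 2, `Cc1c(Cc2cccc(F)c2)c(=O)oc2cc(OCC(O)CN3CCC(C(N)=O)CC3)ccc12`, 53300 nM

In an ADME assay on A549 cells (Homo sapiens) for cytotoxicity, read by CellTiter-Glo (on this read-out lower numbers stand for higher toxicity in this test and higher numbers for lower toxicity in this test), compound 2 gives 53300 nM, and compound 1 gives 38200 nM. The two numbers lie within the usual scatter of each other, so the data do not separate the two compounds in this assay.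

Compound 3, `Cc1c(Cc2ccc(F)cc2Cl)c(=O)oc2cc(OCC(O)CN3CCC(C(N)=O)CC3)ccc12`, has not been measured. It differs from compound 2 by 2-chloro-4-fluorophenyl in place of 3-fluorophenyl on a saturated chain carbon bound to an aromatic carbon. For the measured compounds named here, no measured pair shows this change, so its effect can only be guessed. Given that compound 2 gives 53300 nM, compound 3 is expected to stay in the same region, with a step of a 1.3-fold lower number from compound 2 to compound 3 (0.12 log units; within the scatter) of a size not clearly beyond the scatter. The estimate for compound 3 is 40000 nM, within a range from 15000 nM to 100000 nM.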

Compound 3, half-maximal cytotoxic concentration: 90800 nM
Beside the measured number, compound 3's estimate is 2.3-fold (0.36 log units) below it; the measured number falls inside the stated range.
By their numbers in this assay, from the lowest: compounds 1, 2 and 3 (each within the scatter of the next, the first and the last beyond it).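

For the compounds shown here, this is the first step read at this position: the change from 3-fluorobenzyl to 2-chloro-4-fluorobenzyl gives, in this assay, a 1.7-fold higher number from compound 2 to compound 3 (0.23 log units; within the scatter). The data therefore do not separate the two compounds, and the 2-chloro-4-fluorophenyl group, with its one extra heavy atom, leaves the read-out within the usual scatter on this saturated chain carbon. No available evidence bears on why the two numbers lie so close.

The step carries the chlorine and the changed fluorine placement together, so the compounds shown leave open what a 2-chlorophenyl or a 4-fluorophenyl group would give alone. They also leave open whether an aminophenyl group, a carboxyphenyl group or a longer chain in this place would give a step beyond the scatter.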